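The source may hold more compounds than are shown below. What is called first, only, known or untested is meant among the compounds shown, and "the series" means these compounds.

Compound 1 `CCOC(=O)C1=Cc2ccccc2OC1(OCc1cc(-c2ccc(C)cc2)no1)C(F)(F)F` gives > 150000 nM in a functional assay on DU-145 cells (Homo sapiens) for inhibition, read by MTT assay, with a stated time of 24 h (on this read-out lower numbers stand for stronger inhibition and higher numbers for weaker inhibition), a limit of the assay rather than a number.
Compound 2 `CCOC(=O)C1=Cc2ccccc2OC1(OCc1cn(-c2cccc(OC)c2)nn1)C(F)(F)F` gives > 150000 nM in this assay, again only a limit.
Compound 3 `CCOC(=O)C1=Cc2ccccc2OC1(OCc1cc(-c2ccc3ccccc3c2)no1)C(F)(F)F` gives 71800 nM in this assay.

Within the data shown here, compound 2 therefore stands at the limit, and the only firm number among the three is that of compound 3; within this small set the limit of > 150000 nM in this assay, at which 2 of the 3 values shown sit, is the fuller picture. Among the measured compounds shown here, the one measured step, an at least 2.0-fold lower number from compound 1 to compound 3 (0.31 log units; beyond the scatter), is the sole change with a number attached, and it sits on a different five-membered ring than the change now followed. Compound 4 `CCOC(=O)C1=Cc2ccccc2OC1(OCc1cn(CC(=O)Nc2ccccc2Br)nn1)C(F)(F)F` is compound 2 with ((2-bromophenyl)carbamoyl)methyl in place of 3-methoxyphenyl on an aromatic nitrogen. For the measured compounds named here, no measured step touches this ring nitrogen, so the size and direction of the step can only be guessed from how weak all three compounds are. Compound 4 is expected to remain weak, with an estimate of 150000 nM (range 50000 nM to 300000 nM). The step from compound 2 to compound 4 is thus expected to be a number no higher from compound 2 to compound 4 (the limit leaves the size open), with a real chance that compound 4 is again reported only as a limit.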

Compound 4, half-maximal inhibitory concentration: > 150000 nM
Compound 4: no number, only a limit (the forecaster's own chance of this, stated with the estimate: 55%); the middle value lies on the limit itself.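

Compound 4 gives > 150000 nM in this assay, a limit and not a number. Compound 2 also stands at a limit, so no step can be read between these two compounds. Still open, from the compounds shown here alone, is whether ((2-bromophenyl)carbamoyl)methyl in place of 3-methoxyphenyl changes the inhibition at all, and in which direction.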